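Oxan-4-yl in Place of Cyclopropylmethyl on the Amide Nitrogen

A few compounds are considered here, and "the series" means these few. Any claim that something is new, unique, unknown or untested is made for them only; others in the source may bear on it.

Three compounds have been measured in an assay on HEK293 cells for inhibition of sodium- and chloride-dependent glycine transporter 1 (Homo sapiens), read by scintillation proximity assay; on this read-out higher numbers stand for weaker inhibition and lower numbers for stronger inhibition:

Compound 1 `O=C(CN(C(=O)c1ccc(Cl)cc1)C1CCCCC1)Nc1cc(F)cc(F)c1`: 631 nM
Compound 2 `COc1ccc(C(=O)N(Cc2csc(-c3ccccc3)n2)C2CCCCC2)cc1`: 7940 nM
Compound 3 `O=C(CN(CC1CC1)C(=O)c1ccc(-c2ccccn2)cc1)Nc1cc(F)cc(F)c1`: 200 nM

Among these three, compound 3 stands at the lowest number in this assay. Compound 1 is the nearest to it, and its number is higher by a margin beyond the usual scatter; compound 2 lies furthest away, higher still, also well beyond the scatter. No pair of these compounds differs in only one place, so no single-point step can be read from them.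

Compound 4 `O=C(CN(C(=O)c1ccc(-c2ccccn2)cc1)C1CCOCC1)Nc1cc(F)cc(F)c1` has not been measured yet. It differs from compound 3 in one place: oxan-4-yl in place of cyclopropylmethyl on an amide-type nitrogen. Compound 1 carries a cyclohexyl on the corresponding nitrogen together with a different aryl amide, so its number gives only a loose hint of how a saturated six-membered ring on this nitrogen fares. Compound 4 is therefore expected to give about 320 nM, estimated to fall between 110 nM and 950 nM. The estimated step of a 1.6-fold higher number from compound 3 to compound 4 (0.20 log units; within the scatter) is expected to be small, toward a weaker inhibition if anything, and likely near the edge of the scatter.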

Compound 4, half-maximal inhibitory concentration: 1000 nM
Beside the measured number, compound 4's estimate is 3.1-fold (0.49 log units) below it, and the stated range ends below it.
By their numbers in this assay, from the lowest: compound 3; then compounds 1 and 4 (each within the scatter of the next); then compound 2.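

In this assay, within the data shown here, the amide-type nitrogen proves sensitive to the group it carries: oxan-4-yl in place of cyclopropylmethyl gives a 5.0-fold higher number from compound 3 to compound 4 (0.70 log units; beyond the scatter), the only single-place step in this set and one that clears the usual scatter. The change is not a single feature, as a three-membered ring of carbon only leaves and a six-membered ring with one hydrogen-bond acceptor enters, so ring size and the ring oxygen change together. Nothing measured here accounts for the higher number.

On these data alone, it remains open whether the ring size or the ring oxygen matters more. Cyclohexyl or piperidin-4-yl on this nitrogen, with the rest of compound 3 unchanged, would help separate the two, and a longer chain such as n-butyl would show how far an open chain is tolerated.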